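Swapping the charged head group on compound 1

The source may hold more compounds than are shown below. What is called first, only, known or untested is meant among the compounds shown, and "the series" means these compounds.

Compound 1, `Cc1ccc(-n2cc(C(=O)Nc3cc(F)cc(F)c3)c(=O)c3ccc(N(C)C)nc32)cc1OCCCCCCC[N+]1(C)CCCCC1`, is the weakest of the three measured compounds in an assay on LX2 cells for inhibition of COL1A1 promoter (Homo sapiens), read by a luciferase reporter, with a stated time of 24 h, tested at 50 uM (on this read-out lower numbers stand for a weaker effect and higher numbers for a stronger effect at the one concentration tested), where it gives 45.1%. Compound 2, `CN(C)c1ccc2c(=O)c(C(=O)Nc3cc(F)cc(F)c3)cn(-c3ccc(Cl)c(OCCCCCCC[N+]4(C)CCCCC4)c3)c2n1`, gives 90.5%, and compound 3, `Cc1cc(OCCCCCCC[N+](C)(C)C2CCCCC2)cc(-n2cc(C(=O)Nc3cc(F)cc(F)c3)c(=O)c3ccc(N(C)C)nc32)c1`, gives 89.1%. Among the measured compounds shown here, the one single-place step measured, a number 45.4 percentage points higher from compound 1 to compound 2 (beyond the scatter), concerns the aromatic substituent, not the charged end of the chain, so it does not speak directly to the change now considered. Compound 4, `Cc1ccc(-n2cc(C(=O)Nc3cc(F)cc(F)c3)c(=O)c3ccc(N(C)C)nc32)cc1OCCCCCCC[N+](C)(C)C1CCCCC1`, differs from compound 1 by a group of 9 heavy atoms (8 carbon, 1 nitrogen; one six-membered non-aromatic ring of carbon only) in place of a group of 7 heavy atoms (6 carbon, 1 nitrogen; one six-membered non-aromatic ring with 1 hetero atom), on a saturated chain carbon, seven bonds along the chain from an oxygen on an aromatic ring. For the measured compounds named here, compound 3 carries the same entering group on a differently substituted ring and gives 89.1%, but no single step separates it from compound 1. Compound 4 is therefore expected to show a moderate rise, a number 19.9 percentage points higher from compound 1 to compound 4 (beyond the scatter), with an estimated 65% in this assay, ranging from 40% to 90%.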

Compound 4, a percentage reported as inhibition, at one concentration (the size of the read-out at that concentration, not a potency): 61.7%
Estimate against measurement, compound 4: 3.3 percentage points above; measured number inside the range.
By their numbers in this assay, from the lowest: compound 1; then compound 4; then compounds 3 and 2 (each within the scatter of the next).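

In this assay, the charged end of the chain proves to matter on its own: with the rest of the structure unchanged, the group of 9 heavy atoms with a six-membered ring of carbon only, taking the place of the group of 7 heavy atoms with a ring holding 1 hetero atom, gives a number 16.6 percentage points higher from compound 1 to compound 4 (beyond the scatter), a modest step. Both groups carry net charge +1, so this step arises with the charge count unchanged. Nothing available explains the step. From the compounds shown here alone, whether a trimethylammonium head group or a pyrrolidinium ring would behave likewise at this chain end remains open.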